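The source may hold more compounds than are shown below. What is called first, only, known or untested is meant among the compounds shown, and "the series" means these compounds.

Measured compounds:

Compound 1 `Brc1cn2ccnc2c(-c2ccc3ncn(C4CCCCC4)c3c2)n1` in a functional assay on BT-549 cells (Homo sapiens) for inhibition, read by sulforhodamine B assay, with a stated time of 48 h, tested at 10 uM (on this read-out higher numbers stand for more inhibition at the one concentration tested (going by the name of the read-out) and lower numbers for less inhibition), gives 5.16%.
Compound 2 `c1ccc(-c2cn3ccnc3c(-c3ccc4ncn(C5CCCCC5)c4c3)n2)cc1` gives 57.1%.
Compound 3 `COc1ccc(-c2cn3ccnc3c(-c3ccc4ncn(C5CCCCC5)c4c3)n2)cc1` gives 68.9%.

Compound 3 stands highest of the three numbers in this assay: compound 2 lies closest to it, and compound 1 is furthest away. The steps that lead to compound 3 are large at the first stage, a number 63.7 percentage points higher from compound 1 to compound 3 (beyond the scatter), and modest at the second, a number 11.8 percentage points higher from compound 2 to compound 3 (beyond the scatter).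

Compound 4 `O=Cc1ccc(-c2cn3ccnc3c(-c3ccc4ncn(C5CCCCC5)c4c3)n2)cc1` differs from compound 3 in one place: formyl in place of methoxy on an aromatic carbon. Among the compounds with values here, the only measured step that touches this place is the one between compound 2 and compound 3, where methoxy in place of hydrogen on an aromatic carbon gave a modest rise. Within the data shown here, no measured step shows what formyl does at this place, so the direction is uncertain. Since the 4-methoxyphenyl and the phenyl of compound 2 differ only modestly, a substituent change at this position is expected to move the number by little, and compound 4 is expected to stay near compound 3, with a step of about a number 8.9 percentage points lower from compound 3 to compound 4 (within the scatter). Compound 4 is therefore estimated at 60%, within the range 40% to 80%.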

Compound 4, a percentage reported as inhibition, at one concentration (the size of the read-out at that concentration, not a potency): 33.8%
For compound 4 the middle estimate is 26.2 percentage points above the measured one, and the stated range ends above it.
By their numbers in this assay, from the lowest: compound 1; then compound 4; then compound 2; then compound 3.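

In this assay, the aromatic carbon para to a large group proves more sensitive than the phenyl and 4-methoxyphenyl pair suggested: formyl in place of methoxy gives a number 35.1 percentage points lower from compound 3 to compound 4 (beyond the scatter) and formyl in place of hydrogen gives a number 23.3 percentage points lower from compound 2 to compound 4 (beyond the scatter) so that methoxy and formyl move the number in opposite directions from hydrogen. The 4-formylphenyl group nevertheless keeps part of the gain over bromo, with a number 28.6 percentage points higher from compound 1 to compound 4 (beyond the scatter) as the step, though that gain is smaller than the one seen with phenyl or 4-methoxyphenyl. Nothing available here bears on the reason for the drop with formyl.

The compounds shown leave open whether the fall is particular to formyl or also appears with a carboxylic acid, a nitrile or an amine at this place. They also leave open whether a longer ether such as ethoxy would hold or exceed the number of compound 3 68.9% in this assay at this position.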